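The source may hold more compounds than are shown below. What is called first, only, known or untested is meant among the compounds shown, and "the series" means these compounds.

Compound 1 `Cc1ccc(-c2ccc(C(=O)Nc3ccc(Oc4ccnc5[nH]ccc45)cc3)nc2)cc1` and compound 2 `O=C(Nc1ccc(Oc2ccnc3[nH]ccc23)cc1)c1cc(-c2ccccc2)ccn1` differ in their cores, and the difference between the two cores is not broken down here. In a functional assay on A549 cells (Homo sapiens) for cytotoxicity, read by MTT assay, with a stated time of 72 h (on this read-out higher numbers stand for weaker inhibition and lower numbers for stronger inhibition), compound 1 gives only the limit > 10000 nM. In this assay compound 2 gives 2920 nM. Compound 3 `Cc1ccc(-c2ccc(C(=O)Nc3ccc(Oc4ccnc5[nH]ccc45)c(F)c3)nc2)cc1` carries, relative to compound 1, (fluoro in place of hydrogen on an aromatic carbon); in this assay compound 3 gives 2300 nM, so that an at least 4.3-fold lower number from compound 1 to compound 3 (0.63 log units; beyond the scatter), a step that rests on (the limit of > 10000 nM in this assay, at which 1 of the 3 values shown sits). Compound 2 and compound 3 lie within the scatter of each other. Compound 4 `O=C(Nc1ccc(Oc2ccnc3[nH]ccc23)c(F)c1)c1cc(-c2ccccc2)ccn1` is not yet measured and carries the same change relative to compound 2, (fluoro in place of hydrogen on an aromatic carbon). Compound 4 is expected to show a 3.2-fold lower number from compound 2 to compound 4 (0.51 log units; beyond the scatter) in this assay, an expectation resting on an at least 4.3-fold lower number from compound 1 to compound 3 (0.63 log units; beyond the scatter). The estimate for compound 4 is 900 nM, between 300 nM and 2500 nM.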

Compound 4, half-maximal inhibitory concentration: 4950 nM
Compound 4: middle estimate off by 5.5-fold (0.74 log units), on the low side; measured number outside the range, above it.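

In this assay fluoro in place of hydrogen gives a 1.7-fold higher number from compound 2 to compound 4 (0.23 log units; within the scatter) and so leaves no step beyond the scatter on the core of compound 2. The change therefore does not carry over unchanged between these two cores: the same change on two cores in this assay, an at least 4.3-fold lower number (0.63 log units; beyond the scatter) from compound 1 to compound 3 and a 1.7-fold higher number (0.23 log units; within the scatter) from compound 2 to compound 4, at least 7.3-fold (0.86 log units) apart, beyond the scatter of two such steps. Compound 1 stands at a limit rather than a number, so the gap between the steps has no exact size, and two pairs set no rule for the series: the limit of > 10000 nM in this assay, at which 1 of the 4 values shown sits.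

The compounds shown leave open how chloro or methoxy on the same aromatic carbon would behave on either core. They also leave open which of the two steps the fluoro change would resemble on any further core.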